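Triazole-linked chromene esters: aryl replacing the amide chain

A few compounds are considered here, and "the series" means these few. Any claim that something is new, unique, unknown or untested is made for them only; others in the source may bear on it.

Compound 1 `CCOC(=O)C1=Cc2ccccc2OC1(OCc1cn(CC(=O)Nc2ccc(C)cc2)nn1)C(F)(F)F` carries an ethyl ester and a trifluoromethyl group on the shared core, with a triazole bearing a ((4-methylphenyl)carbamoyl)methyl group on its aromatic nitrogen. In a functional assay on MCF7 cells (Homo sapiens) for inhibition, read by MTT assay, with a stated time of 24 h (a lower number here means a stronger inhibitor, a higher number a weaker inhibitor), compound 1 gives > 150000 nM, which is a limit of the assay rather than a number. Within the set shown, compound 1 therefore stands at the limit of > 150000 nM in this assay, at which 1 of the 2 values shown sits. Among the measured compounds shown here, the only compound with a numerical reading is compound 2 `Cc1ccc(-c2cc(COC3(C(F)(F)F)Oc4ccccc4C=C3C(=O)O)on2)cc1`, which in this assay gives 30100 nM; no step between compound 1 and compound 2 is defined, since the two differ in more than one place.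

Compound 3 `CCOC(=O)C1=Cc2ccccc2OC1(OCc1cn(-c2ccc(F)c(Cl)c2)nn1)C(F)(F)F` is compound 1 with one change: 3-chloro-4-fluorophenyl in place of ((4-methylphenyl)carbamoyl)methyl on an aromatic nitrogen. The amide donor and acceptor leave with the chain, and a compact halogenated aryl takes their place on the ring nitrogen. For the measured compounds named here, no measured step of this kind exists in the set, so the expected direction rests on the limit alone.

For compound 3 the estimated step from compound 1 is an at least 1.8-fold lower number from compound 1 to compound 3 (0.27 log units; that floor lies within the scatter), a modest gain in inhibition of uncertain size. Compound 3 is thus expected at about 80000 nM in this assay, with a range from 20000 nM to 300000 nM, and a real chance that it again returns only a limit.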

Compound 3, half-maximal inhibitory concentration: 25300 nM
For compound 3 the middle estimate is 3.2-fold (0.50 log units) above the measured one, within the range that was stated.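

In this assay, the aromatic nitrogen of the five-membered ring proves open to change: 3-chloro-4-fluorophenyl in place of ((4-methylphenyl)carbamoyl)methyl gives an at least 5.9-fold lower number from compound 1 to compound 3 (0.77 log units; beyond the scatter). With the ethyl ester and trifluoromethyl group kept, a measurable reading therefore does not depend on the amide chain or on its hydrogen-bond donor and acceptor, and a directly attached halogenated aryl is enough to provide one. The step remains a floor and its true size stays unknown, since the reading of compound 1 is a limit of the assay and not a number: the limit of > 150000 nM in this assay, at which 1 of the 3 values shown sits.

This single change removes the amide chain and brings in the aryl ring and both halogens at once, so the compounds shown cannot assign the gain to any one of these parts; a plain phenyl or a benzyl group on the same nitrogen would begin to separate them. Also open, on these data alone, is whether a basic group at this position, such as a piperidine or another amine carried on a short chain, would be tolerated as well as the halogenated aryl.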